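Ortho-aryl extension of the benzyl piperazine in compound 4

The source may hold more compounds than are shown below. What is called first, only, known or untested is meant among the compounds shown, and "the series" means these compounds.

Measured compounds:
compound 1 `COc1ccccc1CC1(OC)CCN(c2ccc(C(=O)NS(=O)(=O)c3ccc(N[C@H](CCN(C)C)CSc4ccccc4)c([N+](=O)[O-])c3)cc2)CC1` — 1.6 nM
compound 2 `COC1(Cc2ccccc2Br)CCN(c2ccc(C(=O)NS(=O)(=O)c3ccc(N[C@H](CCN(C)C)CSc4ccccc4)c([N+](=O)[O-])c3)cc2)CC1` — 1.5 nM
compound 3 `CN(C)CC[C@H](CSc1ccccc1)Nc1ccc(S(=O)(=O)NC(=O)c2ccc(N3CCN(Cc4ccccc4)CC3)cc2)cc1[N+](=O)[O-]` — 39.8 nM

In an assay on isolated protein for displacement of a labelled ligand from Apoptosis regulator Bcl-2 (Homo sapiens), read by fluorescence polarization (on this read-out higher numbers stand for weaker inhibition and lower numbers for stronger inhibition), compound 3 gives the highest number of the three; compound 1 and compound 2 give much lower numbers, and between those two the change a 1.1-fold lower number from compound 1 to compound 2 (0.03 log units; within the scatter) lies within the scatter. Compound 4 `COc1ccc(-c2ccccc2CN2CCN(c3ccc(C(=O)NS(=O)(=O)c4ccc(N[C@H](CCN(C)C)CSc5ccccc5)c([N+](=O)[O-])c4)cc3)CC2)cc1` arises from compound 3 by 4-methoxyphenyl in place of hydrogen on an aromatic carbon. No measured step in this assay touches that place or that kind of group; the one shown step concerns a different ring and is flat. The differing cores of compound 1 and compound 2 offer no direct guide either. The expectation for compound 4 is therefore a lowering of the number, held loosely, of about a 6.6-fold lower number from compound 3 to compound 4 (0.82 log units; beyond the scatter), giving an estimated 6 nM in a range from 1.5 nM to 25 nM.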

Compound 4, inhibition constant: < 1 nM
Compound 4 was reported as a limit; the forecaster's own chance of this, stated with the estimate: 0%; middle value at least 6.0-fold (0.77 log units) away from the limit.
By their numbers in this assay, from the lowest: compounds 2 and 1 (each within the scatter of the next); then compound 3. At a limit, below all of these: compound 4.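

In this assay, compound 4 gives < 1 nM, which is a limit of the assay and not a number. Going by these compounds alone, the aromatic carbon ortho to a large group, untouched by the earlier compounds, accepts 4-methoxyphenyl in place of hydrogen, with an at least 39-fold lower number from compound 3 to compound 4 (1.59 log units; beyond the scatter). The full size of this step cannot be read at the limit of the read-out: the limit of < 1 nM in this assay, at which 1 of the 4 values shown sits.

Going by these compounds, it remains open whether the added ring alone carries the step or its methoxy group contributes. An amine or a carboxylic acid in place of that methoxy group, or a longer chain there, would test this.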